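A swap on the ring nitrogen of a benzyloxy-substituted core

The source may hold more compounds than are shown below. What is called first, only, known or untested is meant among the compounds shown, and "the series" means these compounds.

Compound 1 `N=C1S/C(=C\c2ccc(OCc3ccccc3)cc2)C(=O)N1c1ccc(Cl)cc1` carries a 4-chlorophenyl group on the amide-type nitrogen of its five-membered ring. In an ADME assay on RAW264.7 cells (Mus musculus) for cytotoxicity, read by MTT assay, with a stated time of 48 h, tested at 50 uM (a higher number here means more inhibition at the concentration tested (going by the name of the read-out), a lower number less inhibition), compound 1 gives 16.4%. Among the three measured compounds this number is the second highest. Compound 2 `N=C1S/C(=C\c2ccc(OCc3ccccc3)cc2)C(=O)N1c1ccc(Cl)cc1Cl` gives 13.8%, and the step of a number 2.6 percentage points lower from compound 1 to compound 2 (within the scatter) stays within the scatter. Compound 3 `N=C1S/C(=C\c2ccc(OCc3ccccc3)cc2)C(=O)N1c1ccccn1` gives 37.2%, and the step of a number 20.8 percentage points higher from compound 1 to compound 3 (beyond the scatter) lies beyond the scatter, as does a number 23.4 percentage points higher from compound 2 to compound 3 (beyond the scatter).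

Compound 4 `Cc1ccc(N2C(=N)S/C(=C\c3ccc(OCc4ccccc4)cc3)C2=O)c(C)c1` differs from compound 1 in one place: 2,4-dimethylphenyl in place of 4-chlorophenyl on an amide-type nitrogen in a ring. The change that bears most closely on this one is the step from compound 1 to compound 2, where a chloro was added on an aromatic carbon of the same group and the read-out moved only within the scatter. The larger changes to compound 3 involve a pyridin-2-yl group, which compound 4 does not carry, so they give little guidance here. Compound 4 is therefore expected to show a step of a number 0.6 percentage points higher from compound 1 to compound 4 (within the scatter) that stays within the scatter. The estimate for compound 4 is 17%, expected to fall between 5% and 30%.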

Compound 4, a percentage reported as inhibition, at one concentration (the size of the read-out at that concentration, not a potency): 36.8%
Estimate against measurement, compound 4: 19.8 percentage points below; the whole stated range lies below it.
By their numbers in this assay, from the lowest: compounds 2 and 1 (each within the scatter of the next); then compounds 4 and 3 (each within the scatter of the next).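

At the amide-type nitrogen in the ring, in this assay, the change to 2,4-dimethylphenyl gives a number 20.4 percentage points higher from compound 1 to compound 4 (beyond the scatter), and the matching comparison with the dichlorinated group gives a number 23 percentage points higher from compound 2 to compound 4 (beyond the scatter), so a large step at this position does not require a ring nitrogen in the incoming group. For the compounds shown here, the third comparison, a number 0.4 percentage points lower from compound 3 to compound 4 (within the scatter), places a group with a six-membered aromatic ring of carbon only level with pyridin-2-yl, which the earlier compounds could not show, and across these four compounds the two groups bearing chloro give the lower numbers, with no compound going against that split. Nothing given here explains why the two methyl groups and the pyridin-2-yl group give matching numbers, or why both stand apart from the chlorinated groups.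

The compounds shown leave open whether both methyl groups are needed, since neither 4-methylphenyl nor plain phenyl is among them. They also leave open how a group such as 4-methoxyphenyl or one carrying a carboxylic acid would behave on this nitrogen, and whether the split between chloro and methyl groups would hold on the wider set.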